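The source may report more compounds than this note shows. Statements on the series, on what has been measured and on what is new or still open speak of the compounds shown alone.

Compound 1 `O=c1cc(NC2CCCCC2)cc(/C=C/c2ccccc2)o1` gives 1.23 uM in a functional assay on DU-145 cells (Homo sapiens) for cytotoxicity, read by MTT assay, with a stated time of 72 h; a higher number here means that more compound is needed for the effect, a lower number that less compound is needed. Compound 2 `COc1ccc(Nc2cc(C)oc(=O)c2)cc1` reaches only a limit of the assay, > 30 uM, that is the limit of > 30 uM in this assay, at which 1 of the 3 values shown sits. Compound 3 `COc1ccc(Nc2cc(C3CCCCC3)oc(=O)c2)cc1` gives 8.61 uM.

Among the two numbers known, compound 3 stands highest, and compound 1 is the nearest. Compound 4 `COc1ccc(Nc2cc(/C=C/c3ccccc3)oc(=O)c2)cc1` differs from compound 3 by 2-phenylethenyl in place of cyclohexyl on an aromatic carbon. For the measured compounds named here, one measured step bears on this position: an at least 3.4-fold lower number from compound 2 to compound 3 (0.54 log units; beyond the scatter), where a larger group replaced a smaller one. Compound 1 already carries the 2-phenylethenyl group at the same place and sits lowest of the numbers shown. A fall in this assay is therefore expected, and the step from compound 3 to compound 4 is estimated as a 3.4-fold lower number from compound 3 to compound 4 (0.54 log units; beyond the scatter). Compound 4 is expected to give about 2.5 uM, between 0.8 uM and 8 uM.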

Compound 4, concentration for half-maximal effect: 0.11 uM
Compound 4: middle estimate off by 23-fold (1.36 log units), on the high side; the whole stated range lies above it.
By their numbers in this assay, from the lowest: compound 4; then compound 1; then compound 3. At a limit, above all of these: compound 2.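

Putting 2-phenylethenyl in place of cyclohexyl next to the ring oxygen gives a 78-fold lower number from compound 3 to compound 4 (1.89 log units; beyond the scatter), a much larger step than the earlier one from methyl to cyclohexyl, so this position is far more responsive than compounds 2 and 3 showed. From methyl the step reads an at least 270-fold lower number from compound 2 to compound 4 (2.43 log units; beyond the scatter), and that figure rests on a limit for compound 2: the limit of > 30 uM in this assay, at which 1 of the 4 values shown sits. With 2-phenylethenyl in place, the group on the nitrogen also counts, as 4-methoxyphenyl in place of cyclohexyl gives an 11-fold lower number from compound 1 to compound 4 (1.05 log units; beyond the scatter).

As far as these compounds go, whether a saturated 2-phenylethyl chain or a plain phenyl at this position would keep so low a number remains open. So does the effect of an amine or a carboxylic acid on the phenyl ring of the 2-phenylethenyl group.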